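Ring in Place of Chain on the Aromatic Nitrogen

A few compounds are considered here, and "the series" means these few. Any claim that something is new, unique, unknown or untested is made for them only; others in the source may bear on it.

compound 1 `Nc1ncnc2c1c(-c1ccc3cc[nH]c3c1)cn2-c1ccc(OCCNCCO)cc1` — 30000 nM
compound 2 `FC(F)(F)c1nn(-c2ccc(Cc3nc[nH]n3)cc2)cc1-c1ccc2cc[nH]c2c1` — 5900 nM
compound 3 `NCCCCn1cc(-c2ccc3cc[nH]c3c2)c(C(F)(F)F)n1` — > 30000 nM

Of the compounds shown here, three have been tested in an assay on isolated protein for inhibition of thyroid peroxidase (Homo sapiens); a lower number here means a stronger inhibitor, a higher number a weaker inhibitor. Compound 1 gives 30000 nM in this assay. Compound 2 gives 5900 nM in this assay. For compound 3 only a limit is known: in this assay compound 3 gives > 30000 nM, and this is a limit of the assay, not a number. It sits at the limit of > 30000 nM in this assay, at which 1 of the 3 values shown sits, so compound 3 stands at the weak end of what has been seen, with no value of its own to place it against compounds 1 and 2.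

Compound 4 `N[C@@H]1CC[C@@H](n2cc(-c3ccc4cc[nH]c4c3)c(C(F)(F)F)n2)C1` has not yet been measured in this assay. It differs from compound 3 in one place: a group of 6 heavy atoms (5 carbon, 1 nitrogen; one five-membered non-aromatic ring of carbon only) in place of a group of 5 heavy atoms (4 carbon, 1 nitrogen; no ring), on an aromatic nitrogen. Going by the values given here, no step between two measured compounds covers a change of this kind, so there is nothing in the data to set its size or direction.

Compound 4 is expected to give 20000 nM in this assay, within a range from 5000 nM to 60000 nM. The step of an at least 1.5-fold lower number from compound 3 to compound 4 (0.17 log units; that floor lies within the scatter) is expected to be small, not clearly beyond the usual scatter, since compound 3 gives only a limit at > 30000 nM and the change keeps the same count of donors and acceptors.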

Compound 4, half-maximal inhibitory concentration in the thyroid peroxidase assay: > 30000 nM
Compound 4 ended at the assay's limit; the forecaster's own chance of this, stated with the estimate: 45%; middle value at least 1.5-fold (0.17 log units) away from the limit.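

In the thyroid peroxidase assay compound 3 gives > 30000 nM and this is a limit of the assay, not a number. In the thyroid peroxidase assay compound 4 gives > 30000 nM and this too is a limit of the assay, not a number. Going by these compounds alone, no step between the two compounds can be read. The compounds shown leave open whether the five-membered ring in place of 4-aminobutyl changes the result in the thyroid peroxidase assay at all, and in which direction. In a physicochemical assay for solubility, at pH 6.8 (on this read-out lower numbers stand for lower solubility and higher numbers for higher solubility), compound 3 gives 73000 nM and compound 4 gives 587000 nM as measured values.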